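A few compounds are considered here, and "the series" means these few. Any claim that something is new, unique, unknown or untested is made for them only; others in the source may bear on it.

Measured so far in a functional assay on MCF7 cells (Homo sapiens) for inhibition, read by sulforhodamine B assay, with a stated time of 72 h; on this read-out higher numbers stand for weaker inhibition and lower numbers for stronger inhibition:

compound 1 `CC(c1ccc(-c2ccccc2)c(F)c1)c1nnc2n1N=C(c1ccc(C(F)(F)F)cc1)CS2` gives 4300 nM
compound 2 `CC(c1ccc(-c2ccccc2)c(F)c1)c1nnc2n1N=C(c1ccc(Cl)cc1)CS2` gives 8700 nM
compound 3 `COc1ccc2cc(C(C)c3nnc4n3N=C(c3ccc(Cl)cc3)CS4)ccc2c1` gives 10100 nM

Compound 1 and compound 2 share one core; compound 3 and the unmeasured compound 4 `COc1ccc2cc(C(C)c3nnc4n3N=C(c3ccc(C(F)(F)F)cc3)CS4)ccc2c1` share another. The difference between the two cores is not broken down here. Within the first pair the change trifluoromethyl in place of chloro on an aromatic carbon gave a 2.0-fold lower number from compound 2 to compound 1 (0.31 log units; beyond the scatter). Compound 3 and compound 4 differ by trifluoromethyl in place of chloro on an aromatic carbon, and the place is described in the same words, so this is the same change made a second time, the only repeat among the four compounds. Compound 3 sits near compound 2 in this assay. Within the data shown here, for compound 4 a step of similar size is expected, a 2.0-fold lower number from compound 3 to compound 4 (0.31 log units; beyond the scatter), resting on the single earlier step of a 2.0-fold lower number from compound 2 to compound 1 (0.31 log units; beyond the scatter). Compound 4 is therefore estimated at 5000 nM, within 2500 nM to 10000 nM.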

Compound 4, half-maximal inhibitory concentration: 6900 nM
Estimate against measurement, compound 4: 1.4-fold (0.14 log units) below; measured number inside the range.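

The change from 4-chlorophenyl to 4-(trifluoromethyl)phenyl gives a 1.5-fold lower number from compound 3 to compound 4 (0.17 log units; within the scatter) in this assay, so on the core of compound 3 it does not stand clear of the scatter on its own. Set beside the step on the other core, the two readings do not differ measurably: the same change on two cores in this assay, a 2.0-fold lower number (0.31 log units; beyond the scatter) from compound 2 to compound 1 and a 1.5-fold lower number (0.17 log units; within the scatter) from compound 3 to compound 4, 1.4-fold (0.14 log units) apart, within the scatter of two such steps.

This supports carrying the change between these two cores, but two pairs in a single assay establish no general rule for the series.

The compounds shown leave open how a nitrile, an amine or a carboxylic acid in place of chloro would read on either core. They also leave open whether such a group would give a step beyond the scatter on both cores.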